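Replacing the Iodo Group of a Dichloroacetanilide with Methoxy

A few compounds are considered here, and "the series" means these few. Any claim that something is new, unique, unknown or untested is made for them only; others in the source may bear on it.

For the measured compounds named here, compound 2 `O=C(Nc1ccc(I)cc1)C(Cl)Cl` holds the lower of the two numbers so far recorded in a functional assay on A549 cells (Homo sapiens) for antiproliferative activity, read by MTT assay, with a stated time of 72 h; a higher number here means a weaker inhibitor, a lower number a stronger inhibitor: compound 2 gives 12500 nM, whereas compound 1 `O=C(Nc1ccc(F)cc1)C(Cl)Cl` gives 68400 nM. Going by the values given here, the single measured step, a 5.5-fold lower number from compound 1 to compound 2 (0.74 log units; beyond the scatter), is the only comparison available.

The next compound, compound 3 `COc1ccc(NC(=O)C(Cl)Cl)cc1`, is yet to be tested. It differs from compound 2 by methoxy in place of iodo on an aromatic carbon, the change sitting on an aromatic carbon of a six-membered aromatic ring of carbon only. Among the compounds with values here, no measured step swaps a halogen for a methoxy group, so the step between compound 1 and compound 2 bears on it only indirectly: it shows that the substituent at this position shifts the number by a modest amount and that the iodo compound sits at the favourable end of what has been seen. With the iodo group gone, compound 3 is expected to move toward a higher number, by a step of a 2.8-fold higher number from compound 2 to compound 3 (0.45 log units; beyond the scatter) in this assay. The estimate for compound 3 in this assay is 35000 nM, expected to lie between 12000 nM and 100000 nM.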

Compound 3, half-maximal inhibitory concentration: 80900 nM
The estimate for compound 3 lay 2.3-fold (0.36 log units) below the measured number; the range from low to high includes it.
By their numbers in this assay, from the lowest: compound 2; then compounds 1 and 3 (each within the scatter of the next).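

In this assay, methoxy in place of iodo gives a 6.5-fold higher number from compound 2 to compound 3 (0.81 log units; beyond the scatter), so the lower number of compound 2 does not survive this change at the aromatic carbon. Methoxy in place of fluoro gives a 1.2-fold higher number from compound 1 to compound 3 (0.07 log units; within the scatter), which lies within the scatter, so compound 1 and compound 3 cannot be told apart even though fluoro and methoxy are different groups. Among the three substituents, only iodo now stands apart, with compound 2 the strongest of the set, yet nothing measured alongside these numbers accounts for that difference.

The compounds shown leave open whether chloro or bromo at this position would join iodo at the lower number or fall with fluoro and methoxy at the higher one, and so whether the result is particular to iodo or extends to other halogens. They also leave open how an amine, a carboxylic acid or a longer chain such as ethoxy would read here, and whether the advantage of iodo would persist with a change elsewhere on the shared core.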